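A few compounds are considered here, and "the series" means these few. Any claim that something is new, unique, unknown or untested is made for them only; others in the source may bear on it.

Working notes on the series. In a functional assay on MDA-MB-231 cells (Homo sapiens) for antiproliferative activity, read by MTT assay, with a stated time of 24 h (on this read-out higher numbers stand for weaker inhibition and lower numbers for stronger inhibition), compound 1 `O=C([C@H]1Cc2ccccc2N1)N1CCN(c2nccc(Oc3cc(Cl)cc(Cl)c3)n2)CC1` gives > 50000 nM as a limit of the assay. Compound 2 `O=S(=O)(c1ccccc1)N1CCN(c2nccc(Oc3cc(Cl)cc(Cl)c3)n2)CC1` gives > 50000 nM as a limit too. Compound 3 `CC(C)(C)c1ccc(S(=O)(=O)N2CCN(c3nccc(Oc4cc(Cl)cc(Cl)c4)n3)CC2)cc1` gives > 50000 nM as a limit as well, so it holds no number of its own. With the limit of > 50000 nM in this assay, at which 3 of the 3 values shown sit, as the whole record, no order can be drawn among these three compounds.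

The change to compound 4 `COc1ccccc1S(=O)(=O)N1CCN(c2nccc(Oc3cc(Cl)cc(Cl)c3)n2)CC1` is 2-methoxyphenyl in place of 4-(tert-butyl)phenyl on a sulfonyl sulfur and amounts to 2-methoxyphenyl in place of 4-(tert-butyl)phenyl on a sulfonyl sulfur. Among the measured compounds shown here, the only measured step that touches the group on that sulfur is a step that the two limits leave unreadable from compound 2 to compound 3 with tert-butyl in place of hydrogen on an aromatic carbon. For the measured compounds named here, its size cannot be read and it gives no direction, so the new group has no measured precedent to lean on. No step beyond the scatter is expected, and no direction is claimed. The expected step is a number no higher from compound 3 to compound 4 (the limit leaves the size open) in this assay with a further reading at the limit as the likeliest outcome. For compound 4 the estimate is 50000 nM with an expected range from 20000 nM to 100000 nM as the working span.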

Compound 4, half-maximal inhibitory concentration: 16800 nM
For compound 4 the middle estimate is 3.0-fold (0.47 log units) above the measured one; the whole stated range lies above it.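

In this assay, compound 4 is the only compound shown that gives a number rather than a limit, so a group on the sulfonyl sulfur can now be tied to a reading within the range of the assay. Methoxy in place of hydrogen on an aromatic carbon gives an at least 2.9-fold lower number from compound 2 to compound 4 (0.47 log units; beyond the scatter), and 2-methoxyphenyl in place of 4-(tert-butyl)phenyl on a sulfonyl sulfur gives an at least 2.9-fold lower number from compound 3 to compound 4 (0.47 log units; beyond the scatter), so the series gains its first readable direction at this place, while the earlier step with tert-butyl could not be read. Both new steps fix only a smallest size, because the other end of each sits at a limit: the limit of > 50000 nM in this assay, at which 3 of the 4 values shown sit.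

On these data alone, whether the methoxy group itself carries the step stays open, as an ethoxy group, a hydroxyl group or a dimethylamino group in its place would be needed to test this. Also open, as far as these compounds go, is whether the 2-methoxyphenyl group needs the sulfonyl sulfur at all, which a 2-methoxybenzoyl group on the same ring nitrogen would address.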